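This account rests on a few compounds, and the source may have more. Where it says the series, first, only, none or still open, it means among the compounds named here.

Of the compounds shown here, three built on the same sulfonamide core have been tested so far. Compound 1 `O=S(=O)(NCCNCc1cccc2ccccc12)c1cc(C(F)(F)F)cc(C(F)(F)F)c1`, compound 2 `O=S(=O)(NCCCNCc1ccc(Cl)c(C(F)(F)F)c1)c1cc(C(F)(F)F)cc(C(F)(F)F)c1` and compound 3 `O=S(=O)(NCCCNCc1ccc(-c2ccccc2)cc1)c1cc(C(F)(F)F)cc(C(F)(F)F)c1` differ in the chain and in the aryl group attached to its amine end. In a functional assay on PANC-1 cells (Homo sapiens) for inhibition, read by MTT assay, with a stated time of 72 h (on this read-out lower numbers stand for stronger inhibition of growth and higher numbers for weaker inhibition of growth), compound 1 gives 24000 nM. Compound 3 gives 2500 nM in this assay. Compound 2 gives 10000 nM in this assay, which places it second highest of the three numbers: compound 1 stands at a higher number beyond the scatter, and compound 3 stands at a lower number, also beyond the scatter. None of these three pairs differs in only one place, so no single change has yet been isolated.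

Compound 4 `COc1cccc(CNCCCNS(=O)(=O)c2cc(C(F)(F)F)cc(C(F)(F)F)c2)c1` is the next member. It differs from compound 2 in one place: 3-methoxyphenyl in place of 4-chloro-3-(trifluoromethyl)phenyl on a saturated chain carbon bound to an amine nitrogen. Going by the values given here, with no single-point step among the measured compounds to lean on, the expectation rests on the change itself. The step from compound 2 to compound 4 is expected to be a 1.5-fold higher number from compound 2 to compound 4 (0.18 log units; within the scatter), a modest move toward weaker inhibition of growth, close to the edge of the usual scatter. Compound 4 is therefore estimated at 15000 nM in this assay, within a range from 5000 nM to 40000 nM.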

Compound 4, concentration for 50% growth inhibition: 10000 nM
Beside the measured number, compound 4's estimate is 1.5-fold (0.18 log units) above it, within the range that was stated.
By their numbers in this assay, from the lowest: compound 3; then compounds 2 and 4 (each within the scatter of the next); then compound 1.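

In this assay the exchange of 4-chloro-3-(trifluoromethyl)phenyl for 3-methoxyphenyl on a saturated chain carbon bound to an amine nitrogen gives no change at the digits printed from compound 2 to compound 4 (within the scatter). Going by these compounds alone, this is the first comparison that isolates a single change, and it shows that this place accepts two rather different aryl groups without a readable shift in growth inhibition: a group of 8 heavy atoms with 1 hydrogen-bond acceptor stands in for one of 11 heavy atoms with none, and chlorine and fluorine give way to oxygen. No measurement shown here accounts for this lack of separation between the two compounds.

As far as these compounds go, it remains open whether the same holds for aryl groups bearing a carboxylic acid or a primary amine in place of the methoxy group, or whether such groups would move the number beyond the scatter. No pair shown differs in the chain alone, so the effect of a longer chain on growth inhibition also remains unsettled.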